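The source may report more compounds than this note shows. Statements on the series, on what has been measured and on what is new or still open speak of the compounds shown alone.

Measured so far:
compound 1, `Cc1cnn(C(=O)NCc2ccc(OCc3ccccc3)cc2)c1`: > 100000 nM
compound 2, `O=C(NCc1ccc(OCc2ccccc2)cc1)n1cccn1`: > 100000 nM
compound 3, `Cc1cnn(C(=O)N2CCCCC2)c1`: > 100000 nM

Compound 1, `Cc1cnn(C(=O)NCc2ccc(OCc3ccccc3)cc2)c1`, was tested in an assay on membranes from brain for binding affinity to neutral cholesterol ester hydrolase 1 (Mus musculus), read by fluorescence, with stated times of 1 h and 30 min; on this read-out lower numbers stand for stronger inhibition and higher numbers for weaker inhibition. In this assay compound 1 gives > 100000 nM, which is a limit of the assay and not a number. Compound 2, `O=C(NCc1ccc(OCc2ccccc2)cc1)n1cccn1`, in this assay gives > 100000 nM, again a limit. Compound 3, `Cc1cnn(C(=O)N2CCCCC2)c1`, in this assay gives > 100000 nM, also a limit. From compound 1 to compound 2 the change is hydrogen in place of methyl on an aromatic carbon, and the step that the two limits leave unreadable from compound 1 to compound 2 cannot be read, because both values are limits, as the limit of > 100000 nM in this assay, at which 3 of the 3 values shown sit, shows. The difference between the core of compound 1 and the core of compound 3 is not broken down here.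

Compound 4, `O=C(N1CCCCC1)n1cccn1`, has not yet been measured. It differs from compound 3 by hydrogen in place of methyl on an aromatic carbon, the same kind of change as from compound 1 to compound 2, though here the ring atom bears a group of 8 heavy atoms rather than a large group. Because the limit of > 100000 nM in this assay, at which 3 of the 3 values shown sit, shows every measured value at the limit, compound 4 is expected to stay there too, a step that the limit leaves unreadable from compound 3 to compound 4. For compound 4 the estimated value in this assay is 300000 nM, expected between 100000 nM and 1000000 nM.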

Compound 4, half-maximal inhibitory concentration: > 100000 nM
Compound 4: no number, only a limit (the forecaster's own chance of this, stated with the estimate: 90%); the middle value lies beyond the limit too.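

In this assay compound 4 gives > 100000 nM, which is a limit of the assay and not a number. Among the compounds shown here, compound 3 also stands at a limit, so no step between compound 3 and compound 4 can be read: the limit of > 100000 nM in this assay, at which 4 of the 4 values shown sit. The compounds shown leave open how much hydrogen in place of methyl changes inhibition, and which structures would give a measurable number in this assay.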